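The compounds below may be only part of what the source reports. "The series", "measured", "known", "first", "only" and "open" are said of these compounds alone.

Within the data shown here, only two compounds have numbers so far. In a functional assay on HeLa cells (Homo sapiens) for antiproliferative activity, read by MTT assay, with a stated time of 72 h (a lower number here means a stronger inhibitor, a higher number a weaker inhibitor), compound 1 `COc1ncc(-c2ccc3c(c2)NC(=O)CO3)cc1NS(=O)(=O)c1ccc(F)cc1` gives 7110 nM and compound 2 `COc1cccc(N2C(=O)COc3ccc(-c4cnc5ccccc5c4)cc32)c1` gives 11400 nM, and these two values lie within the usual scatter of each other. Compound 1 therefore shares the lowest position with compound 2 rather than standing clearly ahead of it.

Compound 3 `COc1ncc(-c2ccc3c(c2)N(c2ccccc2)C(=O)CO3)cc1NS(=O)(=O)c1ccc(F)cc1` is compound 1 with one change: phenyl in place of hydrogen on an amide-type nitrogen in a ring. Among the measured compounds shown here, no pair of measured compounds differs in just one place, so the data offer no direct precedent for this step. Compound 2, at 11400 nM, also carries an aromatic ring on an amide-type nitrogen in a ring, but it differs from compound 1 elsewhere too, so it gives only weak guidance.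

A moderate move towards a lower number in this assay is expected, though this is a tentative judgement, and the expected step is a 2.8-fold lower number from compound 1 to compound 3 (0.45 log units; beyond the scatter). For compound 3 the estimated value is 2500 nM, with an expected range from 400 nM to 11000 nM.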

Compound 3, half-maximal inhibitory concentration: 1530 nM
Estimate against measurement, compound 3: 1.6-fold (0.21 log units) above; the measured number falls inside the stated range.
By their numbers in this assay, from the lowest: compound 3; then compounds 1 and 2 (each within the scatter of the next).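

Among these compounds, the amide-type nitrogen in this ring does not need to keep its hydrogen: in this assay, placing phenyl there gives a 4.6-fold lower number from compound 1 to compound 3 (0.67 log units; beyond the scatter), a step beyond the usual scatter and the only single-place change that can be read directly. This position therefore accepts a six-membered aromatic ring of carbon only, adding six heavy atoms but no hydrogen-bond donors or acceptors, and the number falls rather than rises. No measurement is available that explains this drop, so the step records what happens at this position and not why it happens.

A single replacement cannot show whether the lower number is particular to phenyl or would follow from other groups on this nitrogen. A small methyl group, a benzyl group, a longer alkyl chain or a chain ending in an amine at the same position would help to separate those possibilities, and the step seen here cannot predict how any of them would behave.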